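Swapping the Aryl Group on a Sulfonamide

The source may report more compounds than this note shows. Statements on the series, on what has been measured and on what is new or still open speak of the compounds shown alone.

compound 1 `COc1ccc(S(=O)(=O)NC(C2=CC(=O)c3c(O)ccc(O)c3C2=O)C(C)C)cc1`: "not determined" (no result reported)
compound 2 `COc1ccc(S(=O)(=O)NC(C)C2=CC(=O)c3c(O)ccc(O)c3C2=O)cc1`: 20 nM

Going by the values given here, in a functional assay on HL-60 cells (Homo sapiens) for cytotoxicity, read by MTT assay (a lower number here means a stronger inhibitor, a higher number a weaker inhibitor), compound 2 gives 20 nM as the only number available. With no result for compound 1, there is nothing yet to rank it against.

Compound 3 (`CC(NS(=O)(=O)c1cccc(Br)c1)C1=CC(=O)c2c(O)ccc(O)c2C1=O`) keeps the core of compound 2 and changes one group: 3-bromophenyl in place of 4-methoxyphenyl on a sulfonyl sulfur. Among the compounds with values here, no measured pair shows what such a swap does, so no step beyond the usual scatter is expected in this assay and no firm direction can be given. This expectation has a single anchor, compound 2 at 20 nM in the same test. The estimated change is a 1.3-fold higher number from compound 2 to compound 3 (0.10 log units; within the scatter) and carries wide margins. For compound 3 the estimated value is 25 nM with an expected range from 7 nM to 90 nM in repeated measurements.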

Compound 3, half-maximal inhibitory concentration: 160 nM
The estimate for compound 3 lay 6.4-fold (0.81 log units) below the measured number; the whole stated range lies below it.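

The aryl group on the sulfonyl sulfur is not a neutral place to make changes: in this assay, putting 3-bromophenyl in place of 4-methoxyphenyl gives an 8.0-fold higher number from compound 2 to compound 3 (0.90 log units; beyond the scatter). The rest of compound 2 stays the same in compound 3, so this step belongs to the aryl swap alone. However, the swap changes both the substituent and its ring position at once, and nothing available here explains the step.

From the compounds shown here alone, it remains open whether the substituent or its ring position matters more, a question that 4-bromophenyl and 3-methoxyphenyl would help to separate. Going by these compounds, it is also open how plain phenyl or a pyridine ring would behave here, and whether any such swap would lower the number rather than raise it.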